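Metabolic stability notes: two carbapenem-type esters and one open acid

The source may report more compounds than this note shows. Statements on the series, on what has been measured and on what is new or still open speak of the compounds shown alone.

Measured so far:
- compound 1 `COC(=O)OCOC(=O)C1=C(S[C@@H]2CN[C@H](C(=O)Nc3cccc(C(=O)OCOC(=O)OC)c3)C2)[C@H](C)[C@@H]2[C@@H]([C@@H](C)O)C(=O)N12`: > 95%
- compound 2 `CC(C)OC(=O)C1=C(S[C@@H]2CN[C@H](C(=O)Nc3cccc(C(=O)O)c3)C2)[C@H](C)[C@@H]2[C@@H]([C@@H](C)O)C(=O)N12`: > 95%

In an ADME assay for metabolic stability, read by LC-MS, with a stated time of 3 h, at pH 6.5, tested at 50 uM (on this read-out higher numbers stand for a more stable compound and lower numbers for a less stable compound), compound 1 gives > 95%, which is a limit of the assay and not a number. Compound 2 gives > 95% in this assay, again a limit. Both values therefore sit at the limit of > 95% in this assay, at which 2 of the 2 values shown sit, so the two measured compounds cannot be separated on what is shown, and no step between them can be read.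

Compound 3 `COC(=O)OCOC(=O)C1=C(S[C@@H]2CN[C@H](C(=O)Nc3cccc(C(=O)O)c3)C2)[C@H](C)[C@@H]2[C@@H]([C@@H](C)O)C(=O)N12` has not yet been measured in this assay. Against compound 2 it differs in one place: ((methoxycarbonyl)oxy)methyl in place of isopropyl on an oxygen next to a carbonyl group. The entering group is the same one that compound 1 carries on its ester oxygen, while the free acid on the anilide is kept from compound 2.

Without any measured step, the expectation for compound 3 rests only on the two limits shown. The step that the limit leaves unreadable from compound 2 to compound 3 is expected to be none beyond the scatter, and compound 3 is estimated at 96% in this assay, within 86% to 100%, most likely reported again as a limit.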

Compound 3, percent of the compound remaining: > 95%
Compound 3 was reported as a limit; the forecaster's own chance of this, stated with the estimate: 80%; the middle value lies beyond the limit too.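

No step among compound 1, compound 2 and compound 3 can be read, because all three stand at one limit of the assay: the limit of > 95% in this assay, at which 3 of the 3 values shown sit.

The compounds shown leave open whether any change on an oxygen next to a carbonyl group would bring a value off this limit in this assay.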